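This account rests on a few compounds, and the source may have more. Where it says the series, first, only, none or still open, it means among the compounds named here.

Compound 1 `Cc1ccc(-c2cc(-c3ccc(Cl)o3)cc(-c3ccsc3)n2)o1` gives 9.1% in an assay on isolated protein for inhibition of DNA topoisomerase 1 (Homo sapiens), tested at 100 uM; on this read-out lower numbers stand for a weaker effect and higher numbers for a stronger effect at the one concentration tested.
Compound 2 `Clc1ccc(-c2cc(-c3ccsc3)nc(-c3ccccn3)c2)o1` gives 0% in this assay.

Going by the values given here, compound 2 holds the lowest of the two numbers, but its only neighbour is compound 1, and the step of a number 9.1 percentage points lower from compound 1 to compound 2 (within the scatter) is within the scatter, so the two compounds cannot be told apart on these readings. Both sit at the weak end of what this assay can report.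

Compound 3 `Clc1cccc(-c2cc(-c3ccc(Cl)o3)cc(-c3ccsc3)n2)c1` has not yet been measured. It differs from compound 2 in one place: 3-chlorophenyl in place of pyridin-2-yl on an aromatic carbon. Among the compounds with values here, only one measured step bears on this change, the exchange of one aromatic group for another on an aromatic carbon of the shared core from compound 1 to compound 2, which gave a number 9.1 percentage points lower from compound 1 to compound 2 (within the scatter). That step produced nothing beyond the scatter, and nothing else in the measurements distinguishes one aromatic group at that site from another. The expected step from compound 2 to compound 3 in this assay is therefore a number 5 percentage points higher from compound 2 to compound 3 (within the scatter), no change beyond the scatter. Compound 3 is expected to give about 5%, estimated to fall between 0% and 20%.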

Compound 3, a percentage reported as inhibition, at one concentration (the size of the read-out at that concentration, not a potency): 0%
Estimate against measurement, compound 3: 5 percentage points above, within the range that was stated.
By their numbers in this assay, from the lowest: compounds 2, 3 and 1 (each within the scatter of the next).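

Replacing pyridin-2-yl with 3-chlorophenyl, on the aromatic carbon next to the ring nitrogen, gives no change at the digits printed from compound 2 to compound 3 (within the scatter) in this assay, so a ring of carbon only bearing a chlorine cannot be told apart here from a ring containing a nitrogen. Against the 5-methylfuran-2-yl group, the same 3-chlorophenyl group gives a number 9.1 percentage points lower from compound 1 to compound 3 (within the scatter), which means that three different aromatic groups at this position now give readings within the scatter of one another, all at the weak end of what the assay can report. No measurement available here explains these readings.

Going by these compounds, it remains open whether a group of another kind at this position, such as an aminomethyl group, a carboxylic acid or a morpholine ring, would give a reading that stands clear of the scatter. Also open, on these data alone, is what the 5-chlorofuran-2-yl and thiophen-3-yl groups contribute, as they stay the same in compound 1, compound 2 and compound 3, and replacing either one could show whether the other parts of the shared core affect the reading.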